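Swapping a Five-Membered Ring for a Pyridin-3-yl Group

A few compounds are considered here, and "the series" means these few. Any claim that something is new, unique, unknown or untested is made for them only; others in the source may bear on it.

Three compounds share one core: compound 1 `Oc1ccc(-c2cc(-c3cccnc3)nc(-c3ccccc3Cl)c2)cc1`, compound 2 `Oc1ccc(-c2cc(-c3ccsc3)nc(-c3cccc(Cl)c3)c2)cc1` and compound 3 `Oc1ccc(-c2cc(-c3cccc(Cl)c3)nc(-c3ccco3)c2)cc1`. In a functional assay on DU-145 cells (Homo sapiens) for cytotoxicity, read by CCK-8 assay and cell counting, with a stated time of 2 days (on this read-out lower numbers stand for stronger inhibition and higher numbers for weaker inhibition), compound 2 gives 6220 nM, and compound 3 gives 5750 nM; for compound 1 the result is "not determined" (no result reported). Among the measured compounds shown here, compound 3 has the lower of the two numbers, yet the only step, a 1.1-fold lower number from compound 2 to compound 3 (0.03 log units; within the scatter), lies within the scatter, so the two cannot be told apart. Compound 4 `Oc1ccc(-c2cc(-c3cccnc3)nc(-c3cccc(Cl)c3)c2)cc1` differs from compound 3 in one place: pyridin-3-yl in place of furan-2-yl on an aromatic carbon. For the measured compounds named here, no measured step introduces a pyridin-3-yl group; the one step that bears on the change, an exchange of one aromatic group for another, stayed within the scatter, so no shift beyond the scatter is expected in this assay. Compound 4 is therefore estimated at 5500 nM, between 2000 nM and 15000 nM, a step of a 1.0-fold lower number from compound 3 to compound 4 (0.02 log units; within the scatter) expected to be negligible.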

Compound 4, half-maximal inhibitory concentration: 22900 nM
Beside the measured number, compound 4's estimate is 4.2-fold (0.62 log units) below it; measured number above the stated range.
By their numbers in this assay, from the lowest: compounds 3 and 2 (each within the scatter of the next); then compound 4.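

At this position, on the aromatic carbon next to the ring nitrogen, furan-2-yl and thiophen-3-yl could not be told apart, but pyridin-3-yl gives a step beyond the scatter in this assay: a 4.0-fold higher number from compound 3 to compound 4 (0.60 log units; beyond the scatter), and likewise a 3.7-fold higher number from compound 2 to compound 4 (0.57 log units; beyond the scatter). The position therefore does respond to an exchange of one aromatic group for another, and both steps point to weaker inhibition. Nothing measured here accounts for this shift. Still open, going by these compounds, is whether the change follows from the six-membered ring or from its nitrogen, and how a phenyl group, an amine or a carboxylic acid would fare at this position.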